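Working notes: the step from compound 2 to compound 4

This account rests on a few compounds, and the source may have more. Where it says the series, first, only, none or still open, it means among the compounds named here.

- compound 1 `N=c1oc2ccccc2cc1C(=O)N/N=C1\C(=O)Nc2ccc(S(=O)(=O)N3CCOCC3)cc21` gives 132000 nM
- compound 2 `O=C1Nc2ccc(S(=O)(=O)N3CCOCC3)cc2/C1=N/c1ccc(O)cc1` gives 259000 nM
- compound 3 `COc1ccc(-c2c(C#N)c(N)n(/N=C3\C(=O)Nc4ccc(S(=O)(=O)N5CCOCC5)cc43)c(=O)c2C#N)cc1` gives 224000 nM

All three values come from an ADME assay on WI-38 cells (Homo sapiens) for cytotoxicity, read by sulforhodamine B assay, with a stated time of 24 h (on this read-out higher numbers stand for weaker inhibition and lower numbers for stronger inhibition), and all lie within the scatter of one another. Compound 2 therefore has no separate standing: its number sits within the scatter of both compound 3 and compound 1, and the three form a single group.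

Compound 4 `N/N=C1\C(=O)Nc2ccc(S(=O)(=O)N3CCOCC3)cc21` has not yet been measured. It carries amino in place of 4-hydroxyphenyl on a double-bonded nitrogen. Going by the values given here, no measured pair isolates a single change, so the size of this step has no direct precedent. Compound 1 (132000 nM) and compound 3 (224000 nM) carry other groups on that nitrogen, yet both remain within the scatter of compound 2 (259000 nM). No step beyond the scatter is therefore expected in this assay. The expected step is a 1.5-fold lower number from compound 2 to compound 4 (0.18 log units; within the scatter) and stays within the scatter. For compound 4 the estimated value is 170000 nM (expected range 80000 nM to 330000 nM).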

Compound 4, half-maximal inhibitory concentration: 391000 nM
For compound 4 the middle estimate is 2.3-fold (0.36 log units) below the measured one; the whole stated range lies below it.
By their numbers in this assay, from the lowest: compounds 1, 3, 2 and 4 (each within the scatter of the next, the first and the last beyond it).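

In this assay, going by these compounds alone, amino in place of 4-hydroxyphenyl on a double-bonded nitrogen gives a 1.5-fold higher number from compound 2 to compound 4 (0.18 log units; within the scatter), the first pair to isolate a single change. At this position, then, the six-membered aromatic ring of 4-hydroxyphenyl can give way to amino with no step beyond the scatter. The earlier compounds shown here could only suggest this, and they differ from one another in more than one place. The data offer no measured basis for explaining this result.

On these data alone, whether another group on this nitrogen, such as a carboxylic acid or a longer alkyl chain, would produce a step beyond the scatter remains open. The compounds shown also leave open how changes elsewhere on the shared core would read in this assay, since no pair here isolates one.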